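Extending the oxadiazole substituent from methyl to propyl

The compounds below may be only part of what the source reports. "The series", "measured", "known", "first", "only" and "open" are said of these compounds alone.

Compound 1 `CCO/N=C/c1cc(C)c(OCCC(C)CCN2CCN(c3ccnc(N)c3)C2=O)c(C)c1` gives 12900 nM in an ADME assay on RD cells (Homo sapiens) for cytotoxicity, read by MTT assay, with a stated time of 24 h; on this read-out lower numbers stand for higher toxicity in this test and higher numbers for lower toxicity in this test. Compound 2 `Cc1cc(-c2noc(C(F)(F)F)n2)cc(C)c1OCCC(C)CCN1CCN(c2ccnc(N)c2)C1=O` reaches only the limit of > 100000 nM in this assay. Compound 3 `Cc1nc(-c2cc(C)c(OCCC(C)CCN3CCN(c4ccnc(N)c4)C3=O)c(C)c2)no1` gives 28800 nM in this assay, the highest of the two numbers recorded, with compound 1 nearest, separated by a 2.2-fold higher number from compound 1 to compound 3 (0.35 log units; beyond the scatter). One value is a limit rather than a number (the limit of > 100000 nM in this assay, at which 1 of the 3 values shown sits).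

Compound 4 `CCCc1nc(-c2cc(C)c(OCCC(C)CCN3CCN(c4ccnc(N)c4)C3=O)c(C)c2)no1` differs from compound 3 by ethyl in place of hydrogen on a saturated chain carbon bound to an aromatic carbon. Within the data shown here, no measured step changes an alkyl chain in this way. The steps that come closest are the swap of a whole group on the aromatic carbon, a 2.2-fold higher number from compound 1 to compound 3 (0.35 log units; beyond the scatter), and the change of the ring substituent itself, an at least 3.4-fold lower number from compound 2 to compound 3 (0.54 log units; beyond the scatter). Both are modest, and the second shows that what sits on this ring can move the number. A small step is therefore expected, a 1.0-fold higher number from compound 3 to compound 4 (0.02 log units; within the scatter), in either direction and possibly within the scatter. For compound 4 the estimate in this assay is 30000 nM, with a range from 12000 nM to 80000 nM.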

Compound 4, half-maximal cytotoxic concentration: 14100 nM
Estimate against measurement, compound 4: 2.1-fold (0.33 log units) above; measured number inside the range.
By their numbers in this assay, from the lowest: compounds 1 and 4 (each within the scatter of the next); then compound 3. At a limit, above all of these: compound 2.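

In this assay, going from 5-methyl-1,2,4-oxadiazol-3-yl to 5-propyl-1,2,4-oxadiazol-3-yl is the first change shown in a plain alkyl chain on this ring, and it moves the read-out towards higher toxicity in this test: a 2.0-fold lower number from compound 3 to compound 4 (0.31 log units; beyond the scatter). The ring-bearing group of compound 4 also no longer stands apart from the ring-free group of compound 1: a 1.1-fold higher number from compound 1 to compound 4 (0.04 log units; within the scatter), so the ring alone does not keep the number high. Propyl in place of trifluoromethyl gives an at least 7.0-fold lower number from compound 2 to compound 4 (0.85 log units; beyond the scatter), a step whose full size stays unknown, as compound 2 stands at a limit, not a number: the limit of > 100000 nM in this assay, at which 1 of the 4 values shown sits.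

Only methyl and propyl are shown as plain alkyl chains on this ring, so it remains open whether ethyl or a longer chain such as butyl would follow the same direction. Going by these compounds, how an amine or a carboxylic acid on this ring would read also remains open.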